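The compounds below may be only part of what the source reports. "The series", "measured", "known", "first", "only" and "open" are said of these compounds alone.

In a functional assay on A549 cells (Homo sapiens) for inhibition (on this read-out higher numbers stand for weaker inhibition and lower numbers for stronger inhibition), compound 1 `CC(C)c1cc(-c2n[nH]c(=O)n2-c2cccc(NC(=O)CCCCCC(=O)NO)c2)c(O)cc1O` gives 1600 nM and compound 2 `CC(C)c1cc(-c2n[nH]c(=O)n2-c2cccc(NC(=O)CCCCCCC(=O)NO)c2)c(O)cc1O` gives 1600 nM. Compound 3 `CC(C)c1cc(-c2n[nH]c(=O)n2-c2ccc(C(=O)NCCCCCCCC(=O)NO)cc2)c(O)cc1O` gives 4600 nM, the highest of the three numbers and beyond the scatter of both others. Compound 4 `CC(C)c1cc(-c2n[nH]c(=O)n2-c2ccc(C(=O)NCCCC(=O)NO)cc2)c(O)cc1O` is still unmeasured, and its difference from compound 3 is hydroxycarbamoyl in place of 4-(hydroxycarbamoyl)butyl on a saturated chain carbon, three bonds along the chain from an amide-type nitrogen. In words, hydroxycarbamoyl replaces 4-(hydroxycarbamoyl)butyl on a saturated chain carbon, three bonds along the chain from an amide-type nitrogen, which shortens the chain carrying the hydroxycarbamoyl group.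

Among the compounds with values here, only one measured step bears on this: no change at the digits printed from compound 1 to compound 2 (within the scatter). That chain change is smaller than the present one and sits in a differently built pair, so it gives only weak guidance for a cut of this size. No measured shortening of comparable size is available, so a moderate rise in the number is expected, with wide uncertainty. The expected step is a 1.5-fold higher number from compound 3 to compound 4 (0.18 log units; within the scatter). For compound 4 the estimate is 7000 nM, with an expected range of 2500 nM to 25000 nM.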

Compound 4, half-maximal inhibitory concentration: 4600 nM
Estimate against measurement, compound 4: 1.5-fold (0.18 log units) above, and the stated range covers the measured number.
By their numbers in this assay, from the lowest: compounds 1 and 2 (each within the scatter of the next); then compounds 3 and 4 (each within the scatter of the next).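

In this assay, the exchange of 4-(hydroxycarbamoyl)butyl for hydroxycarbamoyl on a saturated chain carbon, three bonds along the chain from an amide-type nitrogen, gives no change at the digits printed from compound 3 to compound 4 (within the scatter) and so removes a substantial part of the chain without moving the read-out. The earlier chain step, no change at the digits printed from compound 1 to compound 2 (within the scatter), covered only a small change in a differently built pair, whereas this pair shows that the read-out at this position also holds across a much larger cut. Nothing available explains this flat response.

Only the two chain ends of this pair are shown, so the read-out for intermediate lengths and for a longer chain remains open. Also open, on these data alone, is whether a carboxylic acid or an amine in place of the hydroxycarbamoyl group would leave the number unchanged on this shared core.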